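A few compounds are considered here, and "the series" means these few. Any claim that something is new, unique, unknown or untested is made for them only; others in the source may bear on it.

Values in a functional assay on HepG2 cells (Homo sapiens) for inhibition, with a stated time of 72 h (a lower number here means a stronger inhibitor, a higher number a weaker inhibitor), so far
- compound 1 `Cc1ccc(C)c(NC(=O)Nc2nc(Sc3c[nH]c4ccccc34)cc(N3CCCCC3)n2)c1` gives 6440 nM
- compound 2 `O=C(Nc1ccccc1)Nc1nc(NC2CC2)cc(Sc2c[nH]c3ccccc23)n1` gives 14300 nM
- compound 3 `O=C(Nc1ccc(Cl)cc1)Nc1nc(Sc2c[nH]c3ccccc23)cc(N2CCCC2)n1` gives 7870 nM

The number for compound 3 sits in the middle of the three and lies within the scatter of both compound 1 and compound 2, so no clear separation exists around it.

Compound 4 `O=C(Nc1ccccc1)Nc1nc(Sc2c[nH]c3ccccc23)cc(N2CCCC2)n1` differs from compound 3 at a single place: hydrogen in place of chloro on an aromatic carbon, para to a large group (hydrogen in place of chloro on an aromatic carbon). The 4-chlorophenyl thus becomes phenyl, and the rest of the molecule stays the same.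

For the measured compounds named here, no measured pair isolates this change, so its size cannot be read directly from the series. The nearest evidence is compound 2, which also carries the phenyl and gives 14300 nM but differs from compound 4 elsewhere on the shared core. That value gives only weak support for a slightly higher number.

The expected change is a 1.2-fold higher number from compound 3 to compound 4 (0.08 log units; within the scatter) and is not expected to exceed the scatter.

Compound 4 is expected at 9500 nM with an estimated range of 4500 nM to 20000 nM in this assay once tested.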

Compound 4, half-maximal inhibitory concentration: 11400 nM
Beside the measured number, compound 4's estimate is 1.2-fold (0.08 log units) below it, and the stated range covers the measured number.
By their numbers in this assay, from the lowest: compounds 1, 3, 4 and 2 (each within the scatter of the next, the first and the last beyond it).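

In this assay, the change from 4-chlorophenyl to phenyl can now be read directly, as a 1.4-fold higher number from compound 3 to compound 4 (0.16 log units; within the scatter), so removing the chloro, para to a large group, does not separate the pair. For the compounds shown here, compound 4 also provides the first single-place comparison for the other substituent on the shared core: pyrrolidin-1-yl in place of cyclopropylamino appears as a 1.3-fold lower number from compound 2 to compound 4 (0.10 log units; within the scatter), and this exchange does not separate its pair either. No available measurement bears on the reason for either result.

From the compounds shown here alone, it remains open whether another group at the chloro position, such as methoxy, trifluoromethyl or a carboxylic acid, would give a step beyond the scatter. Going by these compounds, it also remains open whether the chloro step would keep its size with another amine on the shared core, such as morpholine or a dimethylamino group.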